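A few compounds are considered here, and "the series" means these few. Any claim that something is new, unique, unknown or untested is made for them only; others in the source may bear on it.

Measured so far:
compound 1, `COc1ccc2c(c1)c(S(=O)(=O)c1cccc(F)c1)cn2C1CCCNC1` — 10.7 nM
compound 2, `O=S(=O)(c1cccc(F)c1)c1cn(C2CCCNC2)c2ccc(F)cc12` — 4 nM

Of the compounds shown here, two share one core and have been tested in an assay on HeLa cells for displacement of a labelled ligand from 5-hydroxytryptamine receptor 6 (Homo sapiens), with a stated time of 2 h; a higher number here means a weaker inhibitor, a lower number a stronger inhibitor. Compound 1 gives 10.7 nM, and compound 2 gives 4 nM. Among the measured compounds shown here, the one step recorded between them, a 2.7-fold lower number from compound 1 to compound 2 (0.43 log units; beyond the scatter), concerns a fluoro in place of a methoxy on an aromatic carbon. For the measured compounds named here, on these numbers compound 2 stands lowest, with compound 1 as its only neighbour.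

Compound 3, `CN1CCC(n2cc(S(=O)(=O)c3cccc(F)c3)c3cc(F)ccc32)C1`, has not yet been measured. It differs from compound 2 at a different place: 1-methylpyrrolidin-3-yl in place of piperidin-3-yl on an aromatic nitrogen. The group on the aromatic nitrogen changes from a six-membered ring to a five-membered one, and a hydrogen-bond donor is lost while the acceptor count stays the same.

Going by the values given here, no measured step touches this part of the molecule; the step from compound 1 to compound 2 changed an aromatic substituent and says nothing about the ring on the nitrogen. The expectation for compound 3 therefore rests on the ring exchange alone, and a step beyond the scatter cannot be ruled out in either direction. Compound 3 is estimated at 8 nM, within 2 nM to 40 nM, which means an expected step of a 2.0-fold higher number from compound 2 to compound 3 (0.30 log units; within the scatter) in this assay.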

Compound 3, inhibition constant: 5 nM
Compound 3: the middle estimate sits 1.6-fold (0.20 log units) above what was measured, within the range that was stated.
By their numbers in this assay, from the lowest: compounds 2 and 3 (each within the scatter of the next); then compound 1.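

In this assay the exchange of piperidin-3-yl for 1-methylpyrrolidin-3-yl on an aromatic nitrogen gives a 1.3-fold higher number from compound 2 to compound 3 (0.10 log units; within the scatter) and so compound 2 and compound 3 cannot be told apart in this read-out. Among the compounds shown here, this is the first reading at this position, since the earlier step concerned only an aromatic substituent, and it shows that a six-membered ring with 1 hydrogen-bond donor and a five-membered ring with 0 hydrogen-bond donors can stand here with no difference beyond the scatter. Nothing measured here explains this result.

For the compounds shown here, the single step changes ring size and the hydrogen on the ring nitrogen together, so it cannot show what each change does alone, or whether the two have separate effects that happen to cancel; pyrrolidin-3-yl without the methyl and 1-methylpiperidin-3-yl would be the groups to separate them. It also leaves open how far this position stretches beyond these two rings, for instance to an open chain such as 2-aminoethyl, or whether the same exchange would read alike on the methoxy core of compound 1.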